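A methoxy swap in a series at the assay limit

The compounds below may be only part of what the source reports. "The series", "measured", "known", "first", "only" and "open" are said of these compounds alone.

Measured in an ADME assay on HS27 cells (Homo sapiens) for antiproliferative activity, read by sulforhodamine B assay, with a stated time of 48 h (on this read-out higher numbers stand for weaker inhibition and lower numbers for stronger inhibition), are these compounds:
compound 1 `O=C(O)c1cccc(-c2ccc3c(c2)cc(C(=O)O)n3O)c1` gives > 100000 nM
compound 2 `O=C(O)c1cc2ccc(-c3ccc(Cl)cc3)cc2n1O` gives > 100000 nM
compound 3 `O=C(O)c1cc2ccc(-c3ccc(Cl)cc3Cl)cc2n1O` gives > 100000 nM

All three values are limits of the assay and not numbers. Compound 2 stands at > 100000 nM which is a limit. Neither compound 1 nor compound 3 gives a number to set beside it.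

Compound 4 `COc1ccc(-c2ccc3cc(C(=O)O)n(O)c3c2)cc1` has yet to be measured. It differs from compound 2 by methoxy in place of chloro on an aromatic carbon, para to a large group (methoxy in place of chloro on an aromatic carbon).

Going by the values given here, only one measured step bears on this change, chloro in place of hydrogen on an aromatic carbon (a step that the two limits leave unreadable from compound 2 to compound 3). That step gives no size to work with (because of the limit of > 100000 nM in this assay, at which 3 of the 3 values shown sit). It is a different swap as well, so it offers only weak guidance.

In this assay no step beyond the scatter is expected. Compound 2 gives > 100000 nM as its limit. The expected change is a number no higher from compound 2 to compound 4 (the limit leaves the size open) as an estimate only. The estimate for compound 4 is 100000 nM with an expected range from 40000 nM to 200000 nM and the assay may well report only a limit again.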

Compound 4, half-maximal inhibitory concentration: > 100000 nM
Compound 4 was reported as a limit; the forecaster's own chance of this, stated with the estimate: 85%; the middle value sits exactly at the limit.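

No step can be read between compound 2 and compound 4 in this assay, so methoxy in place of chloro has no size here, for one reason: the limit of > 100000 nM in this assay, at which 4 of the 4 values shown sit.

The compounds shown leave open how any of these groups affects the read-out, since none of them gives a number in this assay to compare.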